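Alkoxy variation at the aryl oxygen: intrinsic activity notes

The source may report more compounds than this note shows. Statements on the series, on what has been measured and on what is new or still open speak of the compounds shown alone.

Measured so far:
compound 1 `CC(Oc1ccccc1OC1CC1)C1=NCCN1`: 0.6
compound 2 `CC(Oc1ccccc1Br)C1=NCCN1`: 0.4
compound 3 `COc1ccccc1OC(C)C1=NCCN1`: 0.5

All three share a core carrying a second substituent on the aromatic ring, and all were read in an assay on CHO cells with Alpha-2B adrenergic receptor (Homo sapiens) as the target; a higher number here means a larger maximal response, a lower number a smaller maximal response. Compound 3 sits in the middle of the three numbers: compound 1 differs from it by a number 0.10 lower from compound 1 to compound 3 (within the scatter), and the step from compound 2 is a number 0.10 higher from compound 2 to compound 3 (within the scatter), so neither neighbour is separated from compound 3 by more than the scatter. For the measured compounds named here, the only step clearly beyond the scatter is a number 0.20 lower from compound 1 to compound 2 (beyond the scatter), where the oxygen substituent is lost altogether.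

The next compound, compound 4 `C=COc1ccccc1OC(C)C1=NCCN1`, keeps the oxygen in place. The change from compound 3 is vinyl in place of methyl on an oxygen on an aromatic ring. Going by the values given here, the closest precedent is the step between compound 1 and compound 3, where swapping cyclopropyl for methyl on that oxygen gave only a change within the scatter; a vinyl group, intermediate between the two in heavy-atom count, gives no reason to expect more. The bromo comparison does not bear directly, as the oxygen is retained here.

Expectation for compound 4 in this assay: no shift beyond the scatter, a step of a number 0.050 higher from compound 3 to compound 4 (within the scatter). Compound 4 is therefore estimated at 0.55, with a range from 0.4 to 0.7.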

Compound 4, intrinsic activity: the largest response reached, as a fraction of the reference agonist's: 0.45
For compound 4 the middle estimate is 0.10 above the measured one; low and high end bracket the measured number.
By their numbers in this assay, from the lowest: compounds 2, 4, 3 and 1 (each within the scatter of the next, the first and the last beyond it).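

On the oxygen on the aromatic ring, vinyl in place of methyl in this assay gives a number 0.050 lower from compound 3 to compound 4 (within the scatter), so this first unsaturated group at the position leaves the maximal response within the scatter of the methyl compound, and the vinyloxy compound is likewise not separated from the bromo compound by a number 0.050 higher from compound 2 to compound 4 (within the scatter). The new information lies in the comparison with cyclopropyl: a number 0.15 lower from compound 1 to compound 4 (beyond the scatter), whereas methyl in place of cyclopropyl gave only a number 0.10 lower from compound 1 to compound 3 (within the scatter), so a change on this oxygen alone can produce a step beyond the scatter, and retaining the oxygen does not by itself keep the number apart from that of the bromo compound. No measurement is available here that accounts for any of these steps.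

The compounds shown leave open how an ethyl group, which would pair with vinyl, or a longer chain such as propyl or butyl on the same oxygen would read in this assay. Also open, on these data alone, is how an amine or a carboxylic acid at the end of such a chain would read, and whether cyclopropyl remains separated from those groups.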